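Compound 3 to compound 4: a new aromatic group on sulfur

The source may report more compounds than this note shows. Statements on the series, on what has been measured and on what is new or still open speak of the compounds shown alone.

Compound 1 `CCn1c([C@@H](C)NS(=O)(=O)C2CC2)nc2ccc(C(F)(F)F)cc21`: < 3 mL.min-1.g-1, a limit
Compound 2 `CCn1c([C@@H](C)NS(=O)(=O)c2ccc(C)cc2)nc2ccc(C(F)(F)F)cc21`: > 100 mL.min-1.g-1, a limit
Compound 3 `CCn1c([C@@H](C)NS(=O)(=O)c2ccc(C#N)cc2)nc2ccc(C(F)(F)F)cc21`: 34 mL.min-1.g-1

In an ADME assay (liver) for metabolic stability, with Liver microsome (Homo sapiens) as the target, read by LC-MS, using microsomes and NADPH, with a stated time of 5 min, at 37 degrees C (a lower number here means slower removal, a higher number faster removal of the compound), compound 3 gives 34 mL.min-1.g-1, the only figure of the three that is not a limit. Compound 4 `CCn1c([C@@H](C)NS(=O)(=O)c2cccc(Cl)c2)nc2ccc(C(F)(F)F)cc21` carries 3-chlorophenyl in place of 4-cyanophenyl on a sulfonyl sulfur. Both steps away from cyclopropyl were large: an at least 33-fold higher number from compound 1 to compound 2 (1.52 log units; beyond the scatter) and an at least 11-fold higher number from compound 1 to compound 3 (1.05 log units; beyond the scatter). Compound 4 keeps an aromatic ring there, so it is expected to stay well clear of the low limit. The nearest guide, an at least 2.9-fold lower number from compound 2 to compound 3 (0.46 log units; beyond the scatter), was at least modest, and compound 4 has no cyano group. In this assay a modest rise is expected, an estimated 2.1-fold higher number from compound 3 to compound 4 (0.31 log units; beyond the scatter). For compound 4 the estimated value is 70 mL.min-1.g-1, with an expected range of 30 mL.min-1.g-1 to 150 mL.min-1.g-1.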

Compound 4, intrinsic clearance in microsomes: > 100 mL.min-1.g-1
Compound 4: only a limit was reported; the forecaster's own chance of this, stated with the estimate: 25%; middle value at least 1.4-fold (0.15 log units) from the limit.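

Compound 4 shows that a phenyl ring on the sulfonyl sulfur bearing neither methyl nor nitrile also reaches the upper limit of this assay, which leaves 4-cyanophenyl as the only aromatic group shown that stays short of it, with an at least 2.9-fold higher number from compound 3 to compound 4 (0.46 log units; beyond the scatter). The contrast with cyclopropyl holds for a third aromatic group, with an at least 33-fold higher number from compound 1 to compound 4 (1.52 log units; beyond the scatter). The step between compound 2 and compound 4 cannot be read because both stand at a limit: the limit of > 100 mL.min-1.g-1 in this assay, at which 2 of the 4 values shown sit.

Still open, going by these compounds, is how far compound 2 and compound 4 lie past that limit. Also open, on these data alone, is where a pyridine ring or a 4-methoxyphenyl group on the sulfonyl sulfur would fall.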